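From compound 3 to compound 4 on the sulfonyl sulfur

A few compounds are considered here, and "the series" means these few. Any claim that something is new, unique, unknown or untested is made for them only; others in the source may bear on it.

Compound 1 (`O=S(=O)(c1ccccc1)N1CCN(c2nccc(Oc3cc(Cl)cc(Cl)c3)n2)CC1`) gives > 50000 nM in a functional assay on MDA-MB-231 cells (Homo sapiens) for antiproliferative activity, read by MTT assay, with a stated time of 24 h (a higher number here means a weaker inhibitor, a lower number a stronger inhibitor), which is a limit and not a number
Compound 2 (`COc1ccc(S(=O)(=O)N2CCN(c3nccc(Oc4cc(Cl)cc(Cl)c4)n3)CC2)cc1`) gives 46800 nM in this assay
Compound 3 (`O=S(=O)(c1cccnc1)N1CCN(c2nccc(Oc3cc(Cl)cc(Cl)c3)n2)CC1`) gives 24800 nM in this assay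

Among the measured compounds shown here, compound 3 stands level with the only other exact number in this small set. The whole gap is a 1.9-fold lower number from compound 2 to compound 3 (0.28 log units; within the scatter) and so no order can be claimed between them.

The next compound, compound 4 (`N#Cc1ccc(S(=O)(=O)N2CCN(c3nccc(Oc4cc(Cl)cc(Cl)c4)n3)CC2)cc1`), carries 4-cyanophenyl in place of pyridin-3-yl on a sulfonyl sulfur while the rest of the structure stays the same.

The closest measured change is the earlier exchange at that same sulfur, which gave a 1.9-fold lower number from compound 2 to compound 3 (0.28 log units; within the scatter) as its step. Two further steps, an at least 1.0-fold lower number from compound 1 to compound 2 (0.02 log units; that floor lies within the scatter) and an at least 2.0-fold lower number from compound 1 to compound 3 (0.30 log units; that floor lies within the scatter), start from a limit and so give only floors. No measured change at this place has been shown to move the number beyond the scatter.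

With compound 3 and its a 1.9-fold lower number from compound 2 to compound 3 (0.28 log units; within the scatter) as the guide, no step beyond the scatter is expected in this assay and no firm direction can be given. The expected step is a 1.2-fold higher number from compound 3 to compound 4 (0.08 log units; within the scatter) and it stays inside the scatter. For compound 4 the estimated value is 30000 nM with an expected range from 13000 nM to 60000 nM in most repeats.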

Compound 4, half-maximal inhibitory concentration: 24800 nM
Compound 4: middle estimate off by 1.2-fold (0.08 log units), on the high side; low and high end bracket the measured number.
By their numbers in this assay, from the lowest: compounds 3, 4 and 2 (each within the scatter of the next). At a limit, above all of these: compound 1.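

In this assay the swap on the sulfonyl sulfur gives no change at the digits printed from compound 3 to compound 4 (within the scatter) even though pyridin-3-yl leaves and 4-cyanophenyl enters, so a ring of carbon only that carries a nitrile does as well here as a ring with a nitrogen in it. Cyano in place of methoxy on the aromatic carbon gives a 1.9-fold lower number from compound 2 to compound 4 (0.28 log units; within the scatter) and adds a third group at this sulfur with no step beyond the scatter, which means that the exact numbers for compounds 2, 3 and 4 cannot be put in order. Cyano in place of hydrogen gives an at least 2.0-fold lower number from compound 1 to compound 4 (0.30 log units; that floor lies within the scatter) and that is only a floor, since compound 1 stands at a limit and not at a number: the limit of > 50000 nM in this assay, at which 1 of the 4 values shown sits.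

Whether any group on this sulfur can move the number beyond the scatter stays open, as every group shown there is an aromatic ring, and a ring carrying an amine or a carboxylic acid, or a plain butyl chain in place of the ring, is not among them. The compounds shown also all keep the two chlorine atoms of the shared core, so they say nothing about a change at that end of the structure.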